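Compound 3 to compound 4: a drawn stereocentre

The source may hold more compounds than are shown below. What is called first, only, known or untested is meant among the compounds shown, and "the series" means these compounds.

In an ADME assay on MRC5 cells (Homo sapiens) for cytotoxicity, read by fluorescence, with a stated time of 72 h (a lower number here means a stronger inhibitor, a higher number a weaker inhibitor), compound 1 `CC1(COc2ccc(OC(F)(F)F)cc2)Cn2cc([N+](=O)[O-])nc2O1` reads > 64000 nM as a limit of the assay, not a number. Compound 2 `CC1(COCc2ccc(OC(F)(F)F)cc2)Cn2cc([N+](=O)[O-])nc2O1` gives 60000 nM and compound 3 `O=[N+]([O-])c1cnc2n1CC(COc1ccc(OC(F)(F)F)cc1)O2` gives 31000 nM in this assay, two numbers within the scatter of each other.

Compound 4 `O=[N+]([O-])c1cnc2n1C[C@H](COc1ccc(OC(F)(F)F)cc1)O2` keeps the atoms and bonds of compound 3 (the two compounds have the same atoms and bonds; at least one stereo element is drawn with a configuration in one of them and without one in the other: 1 of 1 stereo elements differ; a stereocentre at a saturated ring carbon is drawn without a configuration in compound 3 and R in compound 4): a stereocentre at a saturated ring carbon is drawn without a configuration in compound 3 and R in compound 4. Going by the values given here, no measured pair isolates such a change, so the expectation rests on compound 3 at 31000 nM and is for no shift beyond the scatter. The expected 1.1-fold higher number from compound 3 to compound 4 (0.05 log units; within the scatter) stays inside that scatter. The estimate for compound 4 is 35000 nM (expected range 16000 nM to 64000 nM).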

Compound 4, half-maximal inhibitory concentration: > 64000 nM
Compound 4 gave a limit, no number; the forecaster's own chance of this, stated with the estimate: 25%; middle value at least 1.8-fold (0.26 log units) away from the limit.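

Going by these compounds alone, the stereocentre at the saturated ring carbon is the first place where a change leaves atoms and bonds untouched, and in this assay drawing it as R goes with an at least 2.0-fold higher number from compound 3 to compound 4 (0.31 log units; beyond the scatter). Compound 4 gives > 64000 nM, a limit of the assay and not a number, so the size of this step has only a lower bound: the limit of > 64000 nM in this assay, at which 2 of the 4 values shown sit. The comparison is between a defined and an undefined drawing: the fact that one of compounds 3 and 4 is drawn with a defined configuration and the other without, at the place where they differ.

Still open, as far as these compounds go, is how the S configuration at this carbon reads, and how an amine on the side chain would read in this assay.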